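Chlorophenyl positional swap in a hydrazide series

The compounds below may be only part of what the source reports. "The series", "measured", "known", "first", "only" and "open" are said of these compounds alone.

Measured compounds:
compound 1, `CCCNNC(=O)c1cnc(NCc2cc(Cl)ccc2Cl)nc1`: 83%
compound 2, `CCCNNC(=O)c1cnc(NCc2ccc(Cl)cc2)nc1`: 88%
compound 3, `CCCNNC(=O)c1cnc(NCc2cccc3ccccc23)nc1`: 83%

In an assay on isolated protein for inhibition of histone deacetylase 8 (Homo sapiens), read by fluorescence, with a stated time of 5 min, tested at 10 uM (a lower number here means a weaker effect, a higher number a stronger effect of the compound at the concentration tested), compound 2 gives 88%, the highest of the three numbers, though compound 1 and compound 3 both lie within the usual scatter of it, so no ordering among them can be read from the data. Compound 4, `CCCNNC(=O)c1cnc(NCc2ccccc2Cl)nc1`, has not yet been measured. It differs from compound 2 by 2-chlorophenyl in place of 4-chlorophenyl on a saturated chain carbon bound to a nitrogen on an aromatic ring. Since compound 1, compound 2 and compound 3 all sit within scatter of each other despite different aromatic groups at the same place, this shift of the chlorine is not expected to move the number beyond the scatter in either direction. Compound 4 is therefore estimated at 83%, with a range from 70% to 92%, meaning an expected step of a number 5 percentage points lower from compound 2 to compound 4 (within the scatter).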

Compound 4, a percentage reported as inhibition, at one concentration (the size of the read-out at that concentration, not a potency): 87%
Beside the measured number, compound 4's estimate is 4 percentage points below it, within the range that was stated.
By their numbers in this assay, from the lowest: compounds 1, 3, 4 and 2 (each within the scatter of the next).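

In this assay the shift of the chlorine gives a number 1 percentage points lower from compound 2 to compound 4 (within the scatter), so 2-chlorophenyl and 4-chlorophenyl at this place on a saturated chain carbon bound to a nitrogen on an aromatic ring cannot be told apart. Hydrogen in place of chloro on an aromatic carbon gives a number 4 percentage points higher from compound 1 to compound 4 (within the scatter), so this second chlorine shows no readable effect either. Nothing further is available that bears on these results. As far as these compounds go, whether an amine or a carboxylic acid in place of the chlorine would move the number beyond the scatter remains open. Whether any of these compounds has a stronger or weaker effect at other concentrations also remains open, as the read-out shows only the size of the effect at the one concentration tested.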